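A Bulkier Amide Substituent on a Weak Antiproliferative Scaffold

This account rests on a few compounds, and the source may have more. Where it says the series, first, only, none or still open, it means among the compounds named here.

Among the compounds with values here, compound 1 `CN1CCC(NC(=O)c2ccc(Cn3nc(-c4cnn(C)c4)c4ccccc4c3=O)cc2)CC1` is the only member of this set that returns a number: in a functional assay on LoVo cells (Homo sapiens) for antiproliferative activity, read by MTT assay, with a stated time of 72 h (on this read-out higher numbers stand for weaker inhibition and lower numbers for stronger inhibition), compound 1 gives 83300 nM. Compound 2 `Cc1noc(C)c1-c1nn(Cc2ccc(C(=O)N3CCCCC3)cc2)c(=O)c2ccccc12` returns only a limit of the assay, > 100000 nM. Compound 3 `Cc1noc(C)c1-c1nn(Cc2ccc(C(=O)NC3CCN(C)CC3)cc2)c(=O)c2ccccc12` likewise stops at a limit of the assay, > 100000 nM. Two of the three results thus sit at the limit (the limit of > 100000 nM in this assay, at which 2 of the 3 values shown sit), and compound 1 stands alone with a measured value, and a weak one.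

The step from compound 1 to compound 3 is an at least 1.2-fold higher number from compound 1 to compound 3 (0.07 log units; that floor lies within the scatter), and the step from compound 2 to compound 3 is a step that the two limits leave unreadable from compound 2 to compound 3.

Compound 4 `Cn1cc(-c2nn(Cc3ccc(C(=O)NC4CC(C)(C)N([O])C(C)(C)C4)cc3)c(=O)c3ccccc23)cn1` differs from compound 1 at the amide nitrogen: a group of 11 heavy atoms (9 carbon, 1 nitrogen, 1 oxygen; one six-membered non-aromatic ring with 1 hetero atom) in place of a group of 7 heavy atoms (6 carbon, 1 nitrogen; one six-membered non-aromatic ring with 1 hetero atom), on an amide-type nitrogen. Neither measured step covers this exchange. The step from compound 1 to compound 3 changes an aromatic substituent, and the step from compound 2 to compound 3, though it touches the amide, ends at a limit and cannot be sized. With compound 1 already weak and no readable step pointing either way, no shift beyond the scatter is expected in this assay. The expected step is a 1.2-fold higher number from compound 1 to compound 4 (0.08 log units; within the scatter). Compound 4 is estimated at 100000 nM, in a range from 40000 nM to 250000 nM.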

Compound 4, half-maximal inhibitory concentration: 50100 nM
For compound 4 the middle estimate is 2.0-fold (0.30 log units) above the measured one, within the range that was stated.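

Within the data shown here, the amide-type nitrogen is the first place in this set where an exchange can be read as a number at both ends: in this assay the exchange gives a 1.7-fold lower number from compound 1 to compound 4 (0.22 log units; within the scatter). The 1-methylpiperidin-4-yl group can therefore give way to a larger group that also brings in an oxygen atom, and the two compounds cannot be told apart, with compound 4 remaining as weak as compound 1 on this read-out. Compound 2 and compound 3 stop at a limit of the assay, and the steps that involve those limits cannot be read: the limit of > 100000 nM in this assay, at which 2 of the 4 values shown sit.

Going by these compounds, it remains open whether any group on this amide-type nitrogen, such as a morpholine ring, a carboxylic acid or a longer chain ending in a primary amine, would move the number beyond the scatter in either direction. On these data alone, it is also open whether 3,5-dimethyl-1,2-oxazol-4-yl, paired with the group that compound 4 carries on the amide, would return a number rather than a limit.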